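The source may hold more compounds than are shown below. What is called first, only, known or untested is meant among the compounds shown, and "the series" means these compounds.

Measured in an ADME assay on MT4 cells (Homo sapiens) for cytotoxicity, read by MTT assay; a lower number here means that less compound is tolerated, a higher number that more compound is tolerated:
- compound 1 `Cc1ccccc1C(=O)N(C(=S)OCCN1C(=O)c2ccccc2C1=O)c1ccc(Cl)cc1`: 21000 nM
- compound 2 `O=C1c2ccccc2C(=O)N1CCOC(=S)N(C(=O)c1ccc(C(F)(F)F)cc1)c1ccc(Cl)cc1`: 10000 nM

Of these two compounds, compound 1 holds the higher number, and compound 2 lies modestly under it. Compound 3 `Cc1ccc(N(C(=O)c2ccccc2C)C(=S)OCCN2C(=O)c3ccccc3C2=O)cc1` keeps the core of compound 1 and differs by methyl in place of chloro on an aromatic carbon, which amounts to methyl in place of chloro on an aromatic carbon, turning 4-chlorophenyl into 4-methylphenyl. Among the compounds with values here, only one measured step exists, a 2.1-fold lower number from compound 1 to compound 2 (0.32 log units; beyond the scatter). It lies just beyond the scatter, but it replaces the group on the carbonyl carbon, so it speaks only indirectly to this change. Within the data shown here, no measured pair varies the 4-chlorophenyl group. A small shift in this assay is therefore expected, with no favoured direction and probably none beyond the scatter. The expected step is a 1.0-fold higher number from compound 1 to compound 3 (0.02 log units; within the scatter). For compound 3 the estimated value is 22000 nM, with an expected range of 10000 nM to 50000 nM.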

Compound 3, half-maximal cytotoxic concentration: > 100000 nM
Compound 3: no number, only a limit; the forecaster's own chance of this, stated with the estimate: 10%; at least 4.5-fold (0.65 log units) between middle value and limit.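

The group at the 4-chlorophenyl position turns out to matter in this assay, which the earlier pair could not show, as it varied only the group on the carbonyl carbon. Methyl in place of chloro gives an at least 4.7-fold higher number from compound 1 to compound 3 (0.67 log units; beyond the scatter) and so moves the number beyond the scatter with a single heavy atom exchanged on an aromatic carbon para to a large group. As far as these compounds go, compound 3 gives > 100000 nM, which is a limit of the assay and not a number, so its true value stays unknown: the limit of > 100000 nM in this assay, at which 1 of the 3 values shown sits.

From the compounds shown here alone, whether another group at this position, such as fluoro, methoxy or an amine, would also raise the number stays open. Going by these compounds, it is equally open whether methyl in place of chloro would act alike with the 4-(trifluoromethyl)phenyl group of compound 2 on the carbonyl carbon.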